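Chain extension in iodoacetamide nucleotide series against hexokinase-2

The source may hold more compounds than are shown below. What is called first, only, known or untested is meant among the compounds shown, and "the series" means these compounds.

Measured so far:
compound 1, `O=C(CI)NCCCCNc1ncnc2c1ncn2[C@@H]1O[C@H](COP(=O)(O)OP(=O)(O)OP(=O)(O)O)[C@@H](O)[C@H]1O`: 0%
compound 2, `O=C(CI)NCCCCCC(=O)NCCCCNc1ncnc2c1ncn2[C@@H]1O[C@H](COP(=O)(O)OP(=O)(O)OP(=O)(O)O)[C@@H](O)[C@H]1O`: 0%

In an assay on isolated protein for inhibition of hexokinase-2 (Rattus norvegicus), with a stated time of 6 h, tested at 10 mM (on this read-out lower numbers stand for less inhibition and higher numbers for more inhibition at the one concentration tested (going by the name of the read-out)), compound 1 gives 0%, and compound 2 gives 0%. Compound 1 stands level with compound 2 at the digits shown; the step of no change at the digits printed from compound 1 to compound 2 (within the scatter) lies within the scatter. Compound 3, `O=C(CI)NCCCCCCCNc1ncnc2c1ncn2[C@@H]1O[C@H](COP(=O)(O)OP(=O)(O)OP(=O)(O)O)[C@@H](O)[C@H]1O`, differs from compound 1 by 3-(((iodomethyl)carbonyl)amino)propyl in place of ((iodomethyl)carbonyl)amino on a saturated chain carbon, four bonds along the chain from a nitrogen on an aromatic ring. Among the compounds with values here, the only measured step that lengthens the chain, no change at the digits printed from compound 1 to compound 2 (within the scatter), showed no change, so no step beyond the scatter is expected in this assay from this change either. Compound 3 is therefore expected to give 0%, with a range from -5% to 10%. The expected step is no change at the digits printed from compound 1 to compound 3 (within the scatter).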

Compound 3, a percentage reported as inhibition, at one concentration (the size of the read-out at that concentration, not a potency): 30%
Compound 3: middle estimate off by 30 percentage points, on the low side; measured number above the stated range.
By their numbers in this assay, from the lowest: compounds 1 and 2 (each within the scatter of the next); then compound 3.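

In this assay, within the data shown here, 3-(((iodomethyl)carbonyl)amino)propyl in place of ((iodomethyl)carbonyl)amino on a saturated chain carbon, four bonds along the chain from a nitrogen on an aromatic ring, gives a number 30 percentage points higher from compound 1 to compound 3 (beyond the scatter), the first step beyond the scatter. Lengthening alone does not account for a rise: the extension at the other place, carrying a carbonyl and amide nitrogen, shows no change at the digits printed from compound 1 to compound 2 (within the scatter), and compound 2 goes against any such rule. Nothing available explains the difference between these two steps.

Still open, from the compounds shown here alone, is whether a longer chain at this position raises the number further or lowers it. Also open, going by these compounds, is whether a chloromethyl carbonyl end on the same chain keeps the gain.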